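The compounds below may be only part of what the source reports. "The series", "measured", "known", "first", "only" and "open" are said of these compounds alone.

Compound 3 `CCOC(=O)C1=Cc2ccccc2OC1(OCc1cn(-c2ccc(F)c(Cl)c2)nn1)C(F)(F)F` gives 26300 nM in a functional assay on A549 cells (Homo sapiens) for inhibition, read by MTT assay, with a stated time of 24 h (a lower number here means a stronger inhibitor, a higher number a weaker inhibitor), the lowest of the two numbers available; compound 2 `CCOC(=O)C1=Cc2ccccc2OC1(OCc1cn(CC(=O)Nc2ccc(OC)cc2)nn1)C(F)(F)F` gives 29400 nM, and the gap a 1.1-fold lower number from compound 2 to compound 3 (0.05 log units; within the scatter) lies within the scatter. Compound 1 `CCCCCCCCn1cc(COC2(C(F)(F)F)Oc3ccccc3C=C2C(=O)OCC)nn1` reaches only a limit in this assay, > 150000 nM. Exchanging octyl for 3-chloro-4-fluorophenyl gave an at least 5.7-fold lower number from compound 1 to compound 3 (0.75 log units; beyond the scatter). Compound 4 `CCOC(=O)C1=Cc2ccccc2OC1(OCc1cn(-c2ccc(C)cc2)nn1)C(F)(F)F` carries 4-methylphenyl in place of 3-chloro-4-fluorophenyl on an aromatic nitrogen. Within the data shown here, two measured steps touch this nitrogen: the move away from an octyl chain an at least 5.7-fold lower number from compound 1 to compound 3 (0.75 log units; beyond the scatter) and the swap of the carbamoylmethyl group a 1.1-fold lower number from compound 2 to compound 3 (0.05 log units; within the scatter); neither compares one aryl group with another, so the exchange of one small aryl ring for another is expected to alter little. The step is expected to be a 1.1-fold higher number from compound 3 to compound 4 (0.06 log units; within the scatter), within the scatter. For compound 4 the expected value in this assay is 30000 nM, between 12000 nM and 75000 nM.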

Compound 4, half-maximal inhibitory concentration: 19700 nM
For compound 4 the middle estimate is 1.5-fold (0.18 log units) above the measured one, within the range that was stated.
By their numbers in this assay, from the lowest: compounds 4, 3 and 2 (each within the scatter of the next). At a limit, above all of these: compound 1.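

Among these compounds, the exchange of 3-chloro-4-fluorophenyl for 4-methylphenyl, a 1.3-fold lower number from compound 3 to compound 4 (0.13 log units; within the scatter), is the only comparison of two aryl rings on this nitrogen in this assay, and the two rings are not told apart. The aryl ring of compound 4 and the carbamoylmethyl group of compound 2 are not told apart either: a 1.5-fold lower number from compound 2 to compound 4 (0.17 log units; within the scatter). Only the octyl chain stands apart, an at least 7.6-fold lower number from compound 1 to compound 4 (0.88 log units; beyond the scatter), and this step is a bound, since compound 1 sits at a limit: the limit of > 150000 nM in this assay, at which 1 of the 4 values shown sits.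

Going by these compounds, whether an aryl ring bearing an amine or a carboxylic acid would shift the number remains open. So does the effect of a chain shorter than octyl on this nitrogen.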